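From 4-Fluorophenoxy to 4-Chlorophenoxy

A few compounds are considered here, and "the series" means these few. Any claim that something is new, unique, unknown or untested is made for them only; others in the source may bear on it.

In a functional assay on HepG2 cells (Homo sapiens) for antiproliferative activity, read by MTT assay, with a stated time of 48 h (on this read-out higher numbers stand for weaker inhibition and lower numbers for stronger inhibition), compound 1 (`Cc1ccc2nc(Oc3ccccc3)c(/C=N/NC(=O)Cn3c([N+](=O)[O-])cnc3C)cc2c1`) gives 15100 nM, compound 2 (`Cc1ccc(Oc2nc3ccc(C)cc3cc2/C=N/NC(=O)Cn2c([N+](=O)[O-])cnc2C)cc1`) gives 21900 nM, and compound 3 (`Cc1ccc2nc(Oc3ccc(F)cc3)c(/C=N/NC(=O)Cn3c([N+](=O)[O-])cnc3C)cc2c1`) gives 1560 nM, the lowest number of the three. Compound 4 (`Cc1ccc2nc(Oc3ccc(Cl)cc3)c(/C=N/NC(=O)Cn3c([N+](=O)[O-])cnc3C)cc2c1`) carries chloro in place of fluoro on an aromatic carbon, para to a large group: chloro in place of fluoro on an aromatic carbon. Going by the values given here, three measured steps bear on this change. Fluoro in place of hydrogen gave a 9.7-fold lower number from compound 1 to compound 3 (0.99 log units; beyond the scatter), and fluoro in place of methyl gave a 14-fold lower number from compound 2 to compound 3 (1.15 log units; beyond the scatter). Methyl in place of hydrogen gave a 1.5-fold higher number from compound 1 to compound 2 (0.16 log units; within the scatter). Among the compounds with values here, no chloro compound has yet been measured, so only part of the gain seen with compound 3 is assumed to persist. The expected change is small and upward: a 1.9-fold higher number from compound 3 to compound 4 (0.28 log units; within the scatter). For compound 4 the estimated value is 3000 nM, with an expected range of 900 nM to 12000 nM.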

Compound 4, half-maximal inhibitory concentration: 3180 nM
Estimate against measurement, compound 4: 1.1-fold (0.03 log units) below; measured number inside the range.
By their numbers in this assay, from the lowest: compound 3; then compound 4; then compounds 1 and 2 (each within the scatter of the next).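

In this assay chloro, like fluoro, gives a lower number than hydrogen (a 4.7-fold lower number from compound 1 to compound 4 (0.68 log units; beyond the scatter)) and than methyl (a 6.9-fold lower number from compound 2 to compound 4 (0.84 log units; beyond the scatter)), so at this place on the phenoxy ring the drop is not unique to fluoro. The change from fluoro to chloro itself gives a smaller step in the opposite direction (a 2.0-fold higher number from compound 3 to compound 4 (0.31 log units; beyond the scatter)), which leaves compound 3 with the lowest number of the four. Nothing available accounts for these differences. Open, on these data alone, is whether bromo, methoxy or trifluoromethyl at this place would side with the two halogens or with methyl.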